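This account rests on a few compounds, and the source may have more. Where it says the series, first, only, none or still open, it means among the compounds named here.

Compound 1, `CC(=O)OC[C@H]1O[C@@H](n2cc(-c3cn(Cc4ccc(C(C)C)cc4)nn3)c(=O)[nH]c2=O)C[C@@H]1OC(C)=O`: 96.5%
Compound 2, `CC(=O)OC[C@H]1O[C@@H](n2cc(-c3cc(-c4ccc(C(C)(C)C)cc4)no3)c(=O)[nH]c2=O)C[C@@H]1OC(C)=O`: 53.8%
Compound 3, `CC(=O)OC[C@H]1O[C@@H](n2cc(-c3cc(C)no3)c(=O)[nH]c2=O)C[C@@H]1OC(C)=O`: 102%

All three were tested in a functional assay on HCT-15 cells (Homo sapiens) for cytotoxicity, read by sulforhodamine B assay, tested at 10 uM; a lower number here means less inhibition, a higher number more inhibition at the concentration tested (going by the name of the read-out). Among the compounds with values here, compound 1 gives 96.5%, a value within the usual scatter of the one for compound 3, which gives 102%; compound 2, with 53.8%, sits well below both. Within the data shown here, the only measured step that alters a substituent on the shared core is the one from compound 2 to compound 3, where a number 48.2 percentage points higher from compound 2 to compound 3 (beyond the scatter).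

Compound 4, `CC(=O)OC[C@H]1O[C@@H](n2cc(-c3cn(Cc4ccccc4)nn3)c(=O)[nH]c2=O)C[C@@H]1OC(C)=O`, differs from compound 1 by hydrogen in place of isopropyl on an aromatic carbon. This removes a small branched group from the outer ring of compound 1, a far smaller change than the step from compound 2 to compound 3, and at a different place on the core. Among the measured compounds shown here, since compound 1 already gives a high number with 96.5%, little room for a rise remains, and nothing among the measured compounds points to a large fall. The expectation for compound 4 is therefore a step of a number 4.5 percentage points lower from compound 1 to compound 4 (within the scatter), within the scatter. Compound 4 is estimated at 92%, with a range from 72% to 104%.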

Compound 4, a percentage reported as inhibition, at one concentration (the size of the read-out at that concentration, not a potency): 92.3%
For compound 4 the middle estimate is 0.3 percentage points below the measured one; measured number inside the range.
By their numbers in this assay, from the lowest: compound 2; then compounds 4, 1 and 3 (each within the scatter of the next).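

In this assay, hydrogen in place of isopropyl on the six-membered aromatic ring of carbon only, turning 4-isopropylbenzyl into benzyl, gives a number 4.2 percentage points lower from compound 1 to compound 4 (within the scatter). Within the data shown here, this is the first measured change at this position, and it shows that the high number does not depend on keeping the isopropyl group there. No measurement shown here offers an explanation for this result.

From the compounds shown here alone, it remains open whether an amine or a carboxylic acid on this aromatic carbon, or a longer chain in place of isopropyl, would keep the number this high. With a single concentration and both values near the top of the scale, any difference in potency between the two compounds could also stay hidden.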